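Swapping Isobutyl for Cyclopropylmethyl on a Weak Compound

The source may report more compounds than this note shows. Statements on the series, on what has been measured and on what is new or still open speak of the compounds shown alone.

In a functional assay on HL-60 cells (Homo sapiens) for inhibition (on this read-out higher numbers stand for weaker inhibition and lower numbers for stronger inhibition), compound 1 `COc1ccc(-c2cc(O)nnc2-c2ccc(OC)cc2)cc1` gives 31600 nM, a measured number. Compound 2 `COc1ccc(-c2cc(=O)n(CC(C)C)nc2-c2ccc(OC)cc2)cc1` gives > 100000 nM, which is a limit of the assay and not a number. Going by these compounds, compound 2 therefore stands at the limit of > 100000 nM in this assay, at which 1 of the 2 values shown sits, so its true strength remains unknown. Next comes compound 3 `COc1ccc(-c2cc(=O)n(CC3CC3)nc2-c2ccc(OC)cc2)cc1`, which keeps the core of compound 2 and changes one group: cyclopropyl in place of isopropyl on a saturated chain carbon bound to an aromatic nitrogen. In words, cyclopropyl takes the place of isopropyl on a saturated chain carbon bound to an aromatic nitrogen, which turns isobutyl into cyclopropylmethyl. For the measured compounds named here, no measured pair of compounds shows this kind of swap, so the data offer no direct guide to its size. The expected step of a number no higher from compound 2 to compound 3 (the limit leaves the size open) is small, with no direction beyond the scatter of this assay. Compound 3 is estimated to give 100000 nM, with an expected range from 40000 nM to 250000 nM.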

Compound 3, half-maximal inhibitory concentration: 1800 nM
The estimate for compound 3 lay 56-fold (1.74 log units) above the measured number; the measured number lies below the stated range.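

The change at this place, on a saturated chain carbon bound to an aromatic nitrogen, turns out not to be a quiet one: in this assay it gives an at least 55-fold lower number from compound 2 to compound 3 (1.74 log units; beyond the scatter). Isopropyl and cyclopropyl have the same heavy-atom count and differ in the ring, so this place responds to a swap that adds no heavy atom. The step gives only a lower bound on the real change, because compound 2 has no exact number: the limit of > 100000 nM in this assay, at which 1 of the 3 values shown sits.

The compounds shown leave open whether a larger ring such as cyclobutyl, or a longer straight chain such as butyl, would give a lower or a higher number here. This is also a single pair, so it sets no general rule for the swap on other cores.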